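A few compounds are considered here, and "the series" means these few. Any claim that something is new, unique, unknown or untested is made for them only; others in the source may bear on it.

Measured compounds:
- compound 1, `CCCCC1([C@H](O)/C=C/[C@H]2COC(=O)N2CCSc2nc(C(=O)O)cs2)CCC1`: 73 nM
- compound 2, `CCCCC(C)(C)[C@H](O)/C=C/[C@H]1CCC(=O)N1CCSc1nc(C(=O)O)cs1`: 4.2 nM

Both compounds were tested in an assay on isolated protein for agonist activity at prostaglandin E2 receptor EP4 subtype (Homo sapiens); a higher number here means that more compound is needed for the effect, a lower number that less compound is needed. Compound 1 gives 73 nM in this assay, while compound 2 gives 4.2 nM. Going by the values given here, compound 2 therefore stands at the lowest of the two numbers known; its nearest neighbour, compound 1, sits well above it, and the gap between the two is beyond the scatter of the method. Compounds 1 and 2 differ in several places at once, so what the gap tells is limited to the two values themselves.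

Compound 3, `CCCC[C@H](C)C[C@H](O)/C=C/[C@H]1CCC(=O)N1CCSc1nc(C(=O)O)cs1`, is not yet measured. It is built from the same atoms as compound 2, joined differently: 2-methylhexyl in place of 1,1-dimethylpentyl on a saturated chain carbon bound to a double-bonded chain carbon and an oxygen on a saturated carbon. The change keeps the carbon count of the chain and moves a branch outward along it.

Among the compounds with values here, no single-point step between measured compounds is available to anchor this change. The account expects a modest weakening from compound 2 to compound 3, with the step of a 2.4-fold higher number from compound 2 to compound 3 (0.38 log units; beyond the scatter) estimated to be small and close to the scatter. Compound 3 is estimated at 10 nM in this assay, within a range of 3 nM to 40 nM.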

Compound 3, half-maximal effective concentration: 3 nM
Compound 3: the middle estimate sits 3.3-fold (0.52 log units) above what was measured, and the stated range covers the measured number.
By their numbers in this assay, from the lowest: compounds 3 and 2 (each within the scatter of the next); then compound 1.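

In this assay, putting 2-methylhexyl in place of 1,1-dimethylpentyl on a saturated chain carbon bound to a double-bonded chain carbon and an oxygen on a saturated carbon gives a 1.4-fold lower number from compound 2 to compound 3 (0.15 log units; within the scatter), so the method does not separate these two chains. Going by these compounds alone, this is the first single-place step, and it shows that this place carries either chain, with the same carbon count and the branch moved outward, without a change that can be read in this measurement. Nothing measured here accounts for this result, and no independent information bears on it.

The compounds shown leave open what an unbranched heptyl chain or a chain ending in a phenyl ring would give at this place, and what the opposite configuration at the defined stereocentre of 2-methylhexyl would give. They also leave open how much of the gap between compound 1 and the other two belongs to its chain and how much to its core, as compound 1 differs from them in several places at once.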